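Tetrahydropyranylmethyl benzoates: a phenyl group enters

The compounds below may be only part of what the source reports. "The series", "measured", "known", "first", "only" and "open" are said of these compounds alone.

Measured so far:
compound 1 `O=C(OCC1CCCCO1)c1ccc(-c2ccccc2)cc1`: 32000 nM
compound 2 `O=C(OCC1CCCCO1)c1ccccc1`: 53000 nM

Compound 2 stands at the highest of the two numbers in an assay on membranes from cerebellum for inhibition of Fatty-acid amide hydrolase 1 (Rattus norvegicus); on this read-out higher numbers stand for weaker inhibition and lower numbers for stronger inhibition. Its nearest neighbour is compound 1, and the step between them is within the scatter: a 1.7-fold higher number from compound 1 to compound 2 (0.22 log units; within the scatter). On these two numbers alone, compound 1 and compound 2 cannot be told apart.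

Compound 3 `O=C(OCC1CCCCO1)c1cccc(-c2ccccc2)c1` has not yet been measured. It differs from compound 2 in one place: phenyl in place of hydrogen on an aromatic carbon, on an aromatic carbon of a six-membered aromatic ring of carbon only, meta to a large group.

Within the data shown here, the only measured step that bears on this change is the loss of a phenyl group going from compound 1 to compound 2, a 1.7-fold higher number from compound 1 to compound 2 (0.22 log units; within the scatter), which is within the scatter. Nothing measured here shows what a phenyl group does when it enters meta to a large group rather than elsewhere. The expectation for compound 3 is therefore a step from compound 2 of no size beyond the scatter: a 1.3-fold lower number from compound 2 to compound 3 (0.12 log units; within the scatter). Compound 3 is estimated at 40000 nM in this assay, with a range from 15000 nM to 100000 nM.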

Compound 3, half-maximal inhibitory concentration: 18000 nM
Beside the measured number, compound 3's estimate is 2.2-fold (0.35 log units) above it; measured number inside the range.
By their numbers in this assay, from the lowest: compounds 3, 1 and 2 (each within the scatter of the next, the first and the last beyond it).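

In this assay, among these compounds, the entry of phenyl in place of hydrogen on an aromatic carbon, meta to a large group, gives a 2.9-fold lower number from compound 2 to compound 3 (0.47 log units; beyond the scatter) and so provides the first step that lies beyond the scatter, though only a modest one. The earlier change (from a 1.7-fold higher number from compound 1 to compound 2 (0.22 log units; within the scatter)) stayed within the scatter and gave no readable effect of a phenyl group, whereas at this place the entering phenyl goes with stronger inhibition. Nothing at hand bears on why the step appears at this place.

Left open is whether this step belongs to phenyl as such or would follow any group at the same carbon: a methyl group, an amine or a carboxylic acid there would separate the two readings. Also open, from the compounds shown here alone, is whether the step survives on a changed core, for instance with a longer chain in place of the phenyl group or with the ester linkage replaced by an amide.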